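This account rests on a few compounds, and the source may have more. Where it says the series, first, only, none or still open, it means among the compounds named here.

Compound 1: `CCN(Cc1cccs1)C(=O)COc1ccc(F)cc1`, giving 422 nM in an assay on HEK293 cells for agonist activity at transient receptor potential cation channel subfamily M member 8 (Homo sapiens), read by fluorescence and calcium flux, with a stated time of 15 min; a lower number here means that less compound is needed, a higher number that more compound is needed for the effect.
Compound 2: `CCN(Cc1cccs1)C(=O)COc1ccccc1`, giving 1400 nM in this assay.
Compound 3: `CCN(Cc1cccs1)C(=O)COc1ccc(C(C)C)cc1`, not yet measured.

Compound 2 stands at the highest of the two numbers in this assay; its nearest neighbour is compound 1, which carries a fluoro group where compound 2 has a hydrogen. Among the measured compounds shown here, that single step, a 3.3-fold higher number from compound 1 to compound 2 (0.52 log units; beyond the scatter), is the only measured comparison and it shows that removing the group at this position raised the number beyond the scatter. Compound 3 brings (isopropyl in place of hydrogen on an aromatic carbon), on the aromatic carbon para to a large group. Isopropyl is a different group from fluoro, so the earlier step only suggests that putting something back at this carbon may lower the number. Compound 3 is therefore expected to give 500 nM in this assay, within a range of 150 nM to 2000 nM. The step to compound 3 is expected to be a 2.8-fold lower number from compound 2 to compound 3 (0.45 log units; beyond the scatter).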

Compound 3, half-maximal effective concentration: 397 nM
Estimate against measurement, compound 3: 1.3-fold (0.10 log units) above; the measured number falls inside the stated range.
By their numbers in this assay, from the lowest: compounds 3 and 1 (each within the scatter of the next); then compound 2.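

Isopropyl in place of hydrogen gives a 3.5-fold lower number from compound 2 to compound 3 (0.55 log units; beyond the scatter) in this assay, so the lower number seen with fluoro at this carbon is not unique to fluoro: two different groups both beat hydrogen here. Exchanging one for the other gives a 1.1-fold lower number from compound 1 to compound 3 (0.03 log units; within the scatter), which means that this assay does not separate fluoro from isopropyl, and what counts in these three compounds is that the hydrogen has been replaced, not which of the two groups replaces it. No measurement available here explains why the two groups give such similar numbers.

Going by these compounds, it remains open whether the same holds for quite different groups on this carbon, such as an amine, a carboxylic acid or a longer chain. On these data alone, it is also open whether fluoro or isopropyl would have a similar effect on another carbon of this ring.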